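Adding a methylpiperazine to the shared core

This account rests on a few compounds, and the source may have more. Where it says the series, first, only, none or still open, it means among the compounds named here.

The measured compounds:
Compound 1, `Cn1nc(N)c2c(=O)[nH]c(-c3ccccc3)cc21`: 14%
Compound 2, `CC(=O)Nc1nn(C)c2cc(-c3ccccc3)[nH]c(=O)c12`: 9%

In an assay on isolated protein for inhibition of serine/threonine-protein kinase D2 (Homo sapiens), read by mobility shift assay, tested at 30 uM (a lower number here means less inhibition, a higher number more inhibition at the concentration tested (going by the name of the read-out)), compound 2 gives 9%, the lowest of the two numbers; its nearest neighbour is compound 1, and the step of a number 5 percentage points lower from compound 1 to compound 2 (within the scatter) lies within the scatter. Compound 3, `CC(=O)Nc1nn(C)c2cc(-c3ccc(N4CCN(C)CC4)cc3)[nH]c(=O)c12`, differs from compound 2 by 4-methylpiperazin-1-yl in place of hydrogen on an aromatic carbon. Among the compounds with values here, the only measured step, from compound 1 to compound 2, concerns an acetyl on a ring nitrogen and does not touch the phenyl group, so no measured step bears on this change and its size cannot be read from the data. Both measured numbers are low, and nothing in the data points to a large shift in either direction. Compound 3 is therefore expected to remain low, with the step of a number 6 percentage points higher from compound 2 to compound 3 (within the scatter) estimated as none beyond the scatter. For compound 3 the estimate is 15%, in a range from 0% to 45%.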

Compound 3, a percentage reported as inhibition, at one concentration (the size of the read-out at that concentration, not a potency): 13%
For compound 3 the middle estimate is 2 percentage points above the measured one, within the range that was stated.
By their numbers in this assay, from the lowest: compounds 2, 3 and 1 (each within the scatter of the next).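

Within the data shown here, the earlier compounds varied only a substituent on a nitrogen, whereas this change is the first to reach the six-membered aromatic ring of carbon only. In this assay, placing 4-methylpiperazin-1-yl on an aromatic carbon of that ring, para to a large group, gives a number 4 percentage points higher from compound 2 to compound 3 (within the scatter). The added ring therefore moves the read-out by no more than the scatter at this position, and the data contain nothing that bears on why.

From the compounds shown here alone, whether a carboxylic acid, a primary amine or a longer chain ending in an amine on the same carbon would move the number beyond the scatter remains open. Also open, going by these compounds, is whether 4-methylpiperazin-1-yl would behave the same way on compound 1, which carries no acetyl group.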